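The compounds below may be only part of what the source reports. "The series", "measured", "known", "first", "only" and "open" are said of these compounds alone.

In an assay on HeLa cells for inhibition of Indoleamine 2,3-dioxygenase 1 (Homo sapiens) (on this read-out higher numbers stand for weaker inhibition and lower numbers for stronger inhibition), compound 1 `Cc1ccc(NC(=O)Nc2cc(/C(=N/O)Nc3ccc(F)c(Br)c3)ccc2N(CC(C)C)CC(C)C)cc1` gives 760 nM, and compound 2 `CC(C)CN(CC(C)C)c1ccc(/C(=N/O)Nc2ccc(F)c(Br)c2)cc1NC(=O)Nc1cncnc1` gives 860 nM, the higher of the two numbers, though the step of a 1.1-fold higher number from compound 1 to compound 2 (0.05 log units; within the scatter) lies within the scatter. Compound 3 `CC(C)CN(CC(C)C)c1ccc(/C(=N/O)Nc2ccc(F)c(Br)c2)cc1NC(=O)Nc1ccc(C(F)(F)F)cc1` carries 4-(trifluoromethyl)phenyl in place of pyrimidin-5-yl on an amide-type nitrogen. Going by the values given here, only the step from compound 1 to compound 2 bears on this change, and it showed that swapping the group on this nitrogen between an aryl and a heteroaryl left this assay essentially unchanged. The step of a 1.1-fold lower number from compound 2 to compound 3 (0.03 log units; within the scatter) is therefore expected to stay within the scatter. Compound 3 is estimated at 800 nM, with a range from 350 nM to 1800 nM.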

Compound 3, half-maximal inhibitory concentration: 2090 nM
Estimate against measurement, compound 3: 2.6-fold (0.42 log units) below; measured number outside the range, above it.
By their numbers in this assay, from the lowest: compounds 1 and 2 (each within the scatter of the next); then compound 3.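

In this assay the group on the amide-type nitrogen turns out not to be freely interchangeable, with a 2.4-fold higher number from compound 2 to compound 3 (0.39 log units; beyond the scatter) when 4-(trifluoromethyl)phenyl replaces pyrimidin-5-yl. Trifluoromethyl in place of methyl on an aromatic carbon, a single change on that ring, gives a 2.8-fold higher number from compound 1 to compound 3 (0.44 log units; beyond the scatter) and so is enough to weaken inhibition. Nothing available here explains this shift. Still open, as far as these compounds go, is whether a methoxy group or a chlorine atom on that aromatic carbon would behave like methyl or like trifluoromethyl, and whether a saturated group such as cyclohexyl on this nitrogen would keep the lower numbers of compound 1 and compound 2.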